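The compounds below may be only part of what the source reports. "The series", "measured", "known", "first", "only" and "open" are said of these compounds alone.

In a functional assay (on this read-out lower numbers stand for stronger inhibition and higher numbers for weaker inhibition), compound 1 (`CC(C)=CCOc1cc(O)c2c(c1)OC(c1ccc(Cl)cc1)CC2=O`) gives 7020 nM and compound 2 (`CC(C)=CCOc1cc(O)c2c(c1)OC(c1ccccc1Br)CC2=O`) gives 3820 nM. Within the data shown here, these two numbers lie within the scatter of each other, so compound 2 stands level with the only other measured compound. Compound 3 (`CC(C)=CCOc1cc(O)c2c(c1)OC(c1cccc(Br)c1)CC2=O`) differs from compound 2 by a single change, 3-bromophenyl in place of 2-bromophenyl on a saturated ring carbon next to the ring oxygen: 3-bromophenyl in place of 2-bromophenyl on a saturated ring carbon. Among the measured compounds shown here, only one measured step bears on this, the exchange of 4-chlorophenyl for 2-bromophenyl at that same carbon, which gave a 1.8-fold lower number from compound 1 to compound 2 (0.26 log units; within the scatter). For the measured compounds named here, no measured compound carries the 3-bromophenyl group, so this evidence is thin. Even so, no step beyond the scatter is expected in this assay, and no direction can be firmly expected. The estimated step is a 1.2-fold higher number from compound 2 to compound 3 (0.07 log units; within the scatter). Compound 3 is expected at about 4500 nM, with an estimated range of 1800 nM to 11000 nM.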

Compound 3, half-maximal inhibitory concentration: 4040 nM
Estimate against measurement, compound 3: 1.1-fold (0.05 log units) above; the range from low to high includes it.
By their numbers in this assay, from the lowest: compounds 2, 3 and 1 (each within the scatter of the next).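

Among these compounds, putting 3-bromophenyl in place of 2-bromophenyl on the saturated ring carbon next to the ring oxygen gives a 1.1-fold higher number from compound 2 to compound 3 (0.02 log units; within the scatter), so in this assay these two bromophenyl groups stand level, something the earlier compounds could not show with only one bromophenyl group between them. The exchange of 4-chlorophenyl for 3-bromophenyl gives a 1.7-fold lower number from compound 1 to compound 3 (0.24 log units; within the scatter), so all three halogen-bearing phenyl groups at this carbon now lie within the scatter of one another. No evidence is at hand that would account for this level picture.

From the compounds shown here alone, it remains open whether an unsubstituted phenyl, a methoxyphenyl or a pyridine ring at this carbon would also stay level. Also open, going by these compounds, is whether a change to the shared core, such as a longer chain in place of the existing one, would move the number beyond the scatter.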